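The source may hold more compounds than are shown below. What is called first, only, known or untested is meant among the compounds shown, and "the series" means these compounds.

In a functional assay on BGC-823 cells (Homo sapiens) for antiproliferative activity, read by MTT assay, tested at 5 uM (a lower number here means a weaker effect, a higher number a stronger effect of the compound at the concentration tested), compound 1 `COc1cc(C(=O)N/N=C/c2ccc(F)c(F)c2)cc(OC)c1OC` gives 51.9%, compound 2 `COc1cc(C(=O)N/N=C/c2cccc(F)c2)cc(OC)c1OC` gives 44.8%, and compound 3 `COc1cc(C(=O)N/N=C/c2cccc(C(F)(F)F)c2)cc(OC)c1OC` gives 33.8%. Compound 2 thus stands second highest of the three, separated from compound 1 by a gap within the scatter and from compound 3 by a gap beyond it. The two measured steps are a number 7.1 percentage points lower from compound 1 to compound 2 (within the scatter) and a number 11 percentage points lower from compound 2 to compound 3 (beyond the scatter). Compound 4 `COc1cc(C(=O)N/N=C/c2c(Cl)cccc2Cl)cc(OC)c1OC` differs from compound 2 by 2,6-dichlorophenyl in place of 3-fluorophenyl on a carbon with a double bond to nitrogen. Neither measured step exchanges the whole ring, so both bear on this change only loosely; the step that put trifluoromethyl in place of fluoro lowered the read-out modestly, which leaves a small fall plausible here, though none beyond the scatter can be ruled out. Compound 4 is therefore expected to give 40%, within 22% to 58%. That estimate means an expected step of a number 4.8 percentage points lower from compound 2 to compound 4 (within the scatter).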

Compound 4, a percentage reported as inhibition, at one concentration (the size of the read-out at that concentration, not a potency): 27.8%
Compound 4: the middle estimate sits 12.2 percentage points above what was measured; low and high end bracket the measured number.
By their numbers in this assay, from the lowest: compounds 4 and 3 (each within the scatter of the next); then compounds 2 and 1 (each within the scatter of the next).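

In this assay, putting 2,6-dichlorophenyl on the carbon with a double bond to nitrogen gives a number 17 percentage points lower from compound 2 to compound 4 (beyond the scatter) and a number 24.1 percentage points lower from compound 1 to compound 4 (beyond the scatter) in the second comparison, with 2,6-dichlorophenyl in place of 3,4-difluorophenyl. For the compounds shown here, exchanging the whole ring at this position, which no earlier step covered, thus moves the read-out beyond the scatter against both fluorinated rings. No evidence at hand explains this fall. The compounds shown leave open whether the fall follows from the chlorine atoms themselves or from their placement on the ring. They also leave open how a ring carrying an amine or a carboxylic acid would read at this carbon.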